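The source may report more compounds than this note shows. Statements on the series, on what has been measured and on what is new or still open speak of the compounds shown alone.

In this assay a functional assay on PC-3 cells (Homo sapiens) for inhibition, read by CellTiter-Glo, with a stated time of 72 h (on this read-out higher numbers stand for lower toxicity in this test and lower numbers for higher toxicity in this test), the measured compounds stand as follows:

Compound 1 `CC1=C(C(C)C(=O)N(CCNC(C)C)C(C)C)c2cc(F)ccc2/C1=C\c1ccc([S+](C)[O-])cc1` gives 15200 nM.
Compound 2 `CC1=C(C(C)C(=O)NCCN2CCCCC2)c2cc(F)ccc2/C1=C\c1ccc([S+](C)[O-])cc1` gives 36300 nM.
Compound 3 `CC1=C(C(C)C(=O)NCCN2CCNCC2)c2cc(F)ccc2/C1=C\c1ccc([S+](C)[O-])cc1` gives > 50000 nM, which is a limit of the assay and not a number.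

Compound 3 therefore stands at the upper edge of what has been measured; where its number actually lies is known only through that limit (the limit of > 50000 nM in this assay, at which 1 of the 3 values shown sits). The measured steps were a 2.4-fold higher number from compound 1 to compound 2 (0.38 log units; beyond the scatter) and an at least 3.2-fold higher number from compound 1 to compound 3 (0.51 log units; beyond the scatter), and the comparison an at least 1.3-fold higher number from compound 2 to compound 3 (0.13 log units; that floor lies within the scatter) rests on the same limit, so its size is only a floor.

Compound 4 `CC1=C(C(C)C(=O)N2CCN(c3ccncc3)CC2)c2cc(F)ccc2/C1=C\c1ccc([S+](C)[O-])cc1` differs from compound 3 in one place: 4-(pyridin-4-yl)piperazin-1-yl in place of (2-(piperazin-1-yl)ethyl)amino on a carbonyl carbon. All three measured steps alter the group on the carbonyl carbon, and each of them gave a higher number, or at least a floor pointing that way. Going by the values given here, none of them, however, introduces a change of this kind, and since compound 3 already sits at the limit, no measured step can show how much further the number might move.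

The step of an at least 1.1-fold lower number from compound 3 to compound 4 (0.04 log units; that floor lies within the scatter) is expected to stay within the scatter, with a real chance that only a limit is reported again. For compound 4 the expected value is 45000 nM, with a range from 12000 nM to 150000 nM.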

Compound 4, half-maximal cytotoxic concentration: 10500 nM
The estimate for compound 4 lay 4.3-fold (0.63 log units) above the measured number; the measured number lies below the stated range.
By their numbers in this assay, from the lowest: compounds 4 and 1 (each within the scatter of the next); then compound 2. At a limit, above all of these: compound 3.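

Among the steps on this carbonyl carbon, only those to 4-(pyridin-4-yl)piperazin-1-yl run towards lower numbers in this assay, and they do so beyond the scatter (an at least 4.7-fold lower number from compound 3 to compound 4 (0.67 log units; beyond the scatter); a 3.5-fold lower number from compound 2 to compound 4 (0.54 log units; beyond the scatter)). The same group gives no separation from the isopropyl(2-(isopropylamino)ethyl)amino group of compound 1 (a 1.4-fold lower number from compound 1 to compound 4 (0.16 log units; within the scatter)), so higher numbers are not the only outcome of changing this position, and a group with 0 hydrogen-bond donors can stand level with that of compound 1. Compound 3 has a limit of the assay and not a number, so the size of its step to compound 4 is only a floor: the limit of > 50000 nM in this assay, at which 1 of the 4 values shown sits.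

The change to compound 4 brings in the pyridin-4-yl ring, places the piperazine ring directly on the carbonyl carbon and removes the amide hydrogen all at once, and the compounds shown cannot separate these parts. A 4-phenylpiperazin-1-yl group or a bare piperazin-1-yl group on the same carbonyl carbon would show how much of the step belongs to the pyridine nitrogen and how much to the ring attachment.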